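Aryl replacement on the styryl chain: expectation for compound 4

The compounds below may be only part of what the source reports. "The series", "measured", "known", "first", "only" and "open" are said of these compounds alone.

Compound 1 `Oc1ccc(/C=C/C[C@H]2C[C@@H]([C@@H](O)c3ccccc3)CO[C@@H]2c2ccccc2)cc1` serves as the reference of this small set. In a functional assay on HL-60 cells (Homo sapiens) for cytotoxicity, read by WST assay, with a stated time of 48 h (on this read-out lower numbers stand for stronger inhibition and higher numbers for weaker inhibition), compound 1 gives 7380 nM, the lowest of the two numbers available; the nearest is compound 2 `O[C@@H](c1ccccc1)[C@H]1CO[C@H](c2ccccc2)[C@@H](C/C=C/c2ccc(F)cc2)C1`, which in this assay gives 8110 nM. The step of a 1.1-fold higher number from compound 1 to compound 2 (0.04 log units; within the scatter) is within the scatter, so no order is claimed between these two. Compound 3 `O[C@@H](c1ccccc1)[C@H]1CO[C@H](c2ccccc2)[C@@H](C/C=C/c2cccnc2)C1` is reported only as a limit of this assay, > 100000 nM, rather than as a number (the limit of > 100000 nM in this assay, at which 1 of the 3 values shown sits). The steps of an at least 13-fold higher number from compound 1 to compound 3 (1.13 log units; beyond the scatter) and an at least 12-fold higher number from compound 2 to compound 3 (1.09 log units; beyond the scatter) are both large.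

Compound 4 `O=[N+]([O-])c1ccccc1/C=C/C[C@H]1C[C@@H]([C@@H](O)c2ccccc2)CO[C@@H]1c1ccccc1` has not yet been measured. Relative to compound 1 the change is 2-nitrophenyl in place of 4-hydroxyphenyl on a double-bonded chain carbon bound to a double-bonded chain carbon. Two kinds of measured step bear on it: the small 1.1-fold higher number from compound 1 to compound 2 (0.04 log units; within the scatter), where a substituent on the phenyl ring is exchanged with no effect beyond the scatter, and the large losses toward compound 3, where the carbon-only ring itself is replaced. Compound 4 keeps a carbon-only ring but carries a different substituent, so a modest weakening is expected, at most somewhat beyond the scatter. Compound 4 is therefore expected to give about 12000 nM in this assay, with a range from 4000 nM to 60000 nM. This estimate corresponds to an expected step of a 1.6-fold higher number from compound 1 to compound 4 (0.21 log units; within the scatter).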

Compound 4, half-maximal inhibitory concentration: 7250 nM
For compound 4 the middle estimate is 1.7-fold (0.22 log units) above the measured one; low and high end bracket the measured number.
By their numbers in this assay, from the lowest: compounds 4, 1 and 2 (each within the scatter of the next). At a limit, above all of these: compound 3.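

In this assay this position accepts a wider change than the earlier pair showed: 2-nitrophenyl in place of 4-hydroxyphenyl gives a 1.0-fold lower number from compound 1 to compound 4 (0.01 log units; within the scatter), and 2-nitrophenyl in place of 4-fluorophenyl gives a 1.1-fold lower number from compound 2 to compound 4 (0.05 log units; within the scatter). The hydrogen-bond donor of 4-hydroxyphenyl is therefore not needed to hold the value, and the substituent on the carbon-only ring can be a larger group, named at a different ring position, with no shift beyond the scatter. The only large steps among these compounds come with pyridin-3-yl, and the new one is an at least 13-fold lower number from compound 3 to compound 4 (1.13 log units; beyond the scatter), where compound 3 is a limit and not a number: the limit of > 100000 nM in this assay, at which 1 of the 4 values shown sits.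

On these data alone, what remains open is whether the place of the substituent on the ring matters in itself, which a 4-nitrophenyl group at the same chain carbon would test directly. As far as these compounds go, it is also open whether the loss seen with pyridin-3-yl extends to other ring changes, or whether an aminophenyl or carboxyphenyl group, or a saturated cyclohexyl ring, would be accepted as 2-nitrophenyl is.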